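Working notes: removing a methyl in a paw-edema series

The compounds below may be only part of what the source reports. "The series", "measured", "known", "first", "only" and "open" are said of these compounds alone.

Measured so far:
compound 1 `CNc1nnc(Cn2c(=O)oc3ccc(C)cc32)s1` gives 96%
compound 2 `CCNc1nnc(Cn2c(=O)oc3ccc(C)cc32)s1` gives 94%
compound 3 `CCNC(=S)NNC(=O)Cn1c(=O)oc2ccc(C)cc21` gives 128%

All three were tested in a functional assay on the whole organism with Mus musculus as the target, read by paw edema, with a stated time of 360 min, at a dose of 50 mg/kg by the oral route; a higher number here means a weaker effect of the compound at the dose given, a lower number a stronger effect. Compound 1 and compound 2 share one core, compound 3 carries another; the difference between the two cores is not broken down here. In this assay compound 3 gives the highest of the three numbers, and its steps to compound 1 and to compound 2 both lie beyond the scatter, so of these three its effect at the dose is the weakest.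

Going by the values given here, the one counted step among the measured compounds is hydrogen in place of methyl on a saturated chain carbon bound to a nitrogen on an aromatic ring. It made a number 2 percentage points higher from compound 2 to compound 1 (within the scatter).

Compound 4 `CNC(=S)NNC(=O)Cn1c(=O)oc2ccc(C)cc21` is not yet measured. Against compound 3 it differs by hydrogen in place of methyl on a saturated chain carbon bound to an amide-type nitrogen. This is the same kind of change as that from compound 2 to compound 1, but not the same: there the carbon sits on a nitrogen on an aromatic ring, here on an amide-type nitrogen, and the core is the other one.

Given that the one earlier instance of this change made a number 2 percentage points higher from compound 2 to compound 1 (within the scatter), the expected step is a number 2 percentage points lower from compound 3 to compound 4 (within the scatter), small and within the scatter. For compound 4 the estimate in this assay is 126%. Its expected range runs from 108% to 144%, the width reflecting that the place of the change and the core both differ from the earlier case.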

Compound 4, a percentage reported as activity, at one dose (the size of the read-out at that dose, not a potency): 189%
Beside the measured number, compound 4's estimate is 63 percentage points below it, and the stated range ends below it.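

In this assay the change from ethylamino to methylamino gives a number 61 percentage points higher from compound 3 to compound 4 (beyond the scatter) and so weakens the effect at the dose given on the core of compound 3. Set beside the earlier case, the same change does not carry over in size from one core to the other: the same change on two cores in this assay, a number 2 percentage points higher (within the scatter) from compound 2 to compound 1 and a number 61 percentage points higher (beyond the scatter) from compound 3 to compound 4, 59 percentage points apart, beyond the scatter of two such steps. This does not show what separates the two steps: core and place differ together, with the carbon on a nitrogen on an aromatic ring in one case and on an amide-type nitrogen in the other, and a single pair on each core cannot tell these two differences apart.

The compounds shown leave open how a longer chain such as propyl, or an unsubstituted amino group, in place of the ethylamino or methylamino group would read on either core. Also open, as far as these compounds go, is whether a step of this size returns for the same change on a further core, or at a dose or time other than the one stated, so the step from ethyl to methyl cannot yet be treated as transferable.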